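Thiazole for oxazole in a hydrolase inhibitor series

The compounds below may be only part of what the source reports. "The series", "measured", "known", "first", "only" and "open" are said of these compounds alone.

Measured so far:
compound 1 `Cn1nc2c(=O)n(CC3(O)CCN(Cc4ccc(-c5cnco5)cc4Cl)CC3)cnc2c1-c1ccc(CN)cc1`, 71.6 nM
compound 2 `Cn1nc2c(=O)n(CC3(O)CCN(Cc4ccc(-c5ccco5)cc4Cl)CC3)cnc2c1-c1ccc(CNS(C)(=O)=O)cc1`, 65.3 nM

Among the compounds with values here, in an assay on isolated protein for inhibition of ubiquitin carboxyl-terminal hydrolase 7 (Homo sapiens), with stated times of 30 min and 2 h (a higher number here means a weaker inhibitor, a lower number a stronger inhibitor), compound 1 gives 71.6 nM, the higher of the two numbers so far; compound 2 gives 65.3 nM, and the gap between the two lies within the scatter, so neither is called the stronger. Compound 3 `Cn1nc2c(=O)n(CC3(O)CCN(Cc4ccc(-c5cncs5)cc4Cl)CC3)cnc2c1-c1ccc(CN)cc1` is not yet measured. It differs from compound 1 in one place: 1,3-thiazol-5-yl in place of 1,3-oxazol-5-yl on an aromatic carbon. Within the data shown here, no measured pair here bears on this exchange. The step expected from compound 1 to compound 3 is a 1.0-fold lower number from compound 1 to compound 3 (0.01 log units; within the scatter), none beyond the scatter. For compound 3 the estimate is 70 nM, with a range from 35 nM to 140 nM.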

Compound 3, half-maximal inhibitory concentration: 117 nM
Beside the measured number, compound 3's estimate is 1.7-fold (0.22 log units) below it; the measured number falls inside the stated range.
By their numbers in this assay, from the lowest: compounds 2, 1 and 3 (each within the scatter of the next).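

In this assay, within the data shown here, the first reading on this exchange at the ring position para to a large group is a 1.6-fold higher number from compound 1 to compound 3 (0.21 log units; within the scatter), so sulfur for oxygen in the five-membered ring gives no step beyond the scatter. With the aminomethyl-bearing core held fixed, the 1,3-oxazol-5-yl and 1,3-thiazol-5-yl groups cannot be told apart in this assay. No independent measurement bears on this result.

On these data alone, whether a phenyl ring or a carboxylic acid at this position would stay within the scatter of compound 1 remains open. Also open, as far as these compounds go, is whether the same exchange behaves alike with a methanesulfonamide in place of the aminomethyl group.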